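Methylsulfanyl for methoxycarbonyl on a quinoline-urea scaffold

The source may hold more compounds than are shown below. What is called first, only, known or untested is meant among the compounds shown, and "the series" means these compounds.

Compounds measured so far:
compound 1 `Cc1cc(NC(=O)Nc2ccc(C(=O)O)cc2)c2ccccc2n1` gives > 25000 nM in an ADME assay on HepG2 cells (Homo sapiens) for cytotoxicity, with a stated time of 72 h; on this read-out lower numbers stand for an effect already at smaller amounts and higher numbers for an effect only at larger amounts of compound; this is a limit, not a number.
Compound 2 `Cc1ccc(NC(=O)Nc2cc(C)nc3ccccc23)cc1` gives > 25000 nM in this assay, again a limit.
Compound 3 `COC(=O)c1ccc(NC(=O)Nc2cc(C)nc3ccccc23)cc1` gives 20000 nM in this assay.

Within the data shown here, compound 3 therefore holds the only actual number in this assay; the other two values are limits (the limit of > 25000 nM in this assay, at which 2 of the 3 values shown sit). The step from compound 2 to compound 3, methoxycarbonyl in place of methyl on an aromatic carbon, reads an at least 1.2-fold lower number from compound 2 to compound 3 (0.09 log units; that floor lies within the scatter). The step from compound 1 to compound 3, methyl in place of hydrogen on an oxygen next to a carbonyl group, reads an at least 1.2-fold lower number from compound 1 to compound 3 (0.09 log units; that floor lies within the scatter). Both steps only set floors, and both floors lie within the scatter.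

Compound 4 `CSc1ccc(NC(=O)Nc2cc(C)nc3ccccc23)cc1` differs from compound 3 as follows: methylsulfanyl in place of methoxycarbonyl on an aromatic carbon. The methoxycarbonyl that distinguished compound 3 from compound 2 leaves, and a small methylsulfanyl takes its place. Since compound 2, without that group, sat at a limit, and the measured steps are at best floors within the scatter, no step beyond the scatter is expected in this assay; the expected step is a 1.3-fold higher number from compound 3 to compound 4 (0.10 log units; within the scatter). Compound 4 is estimated at 25000 nM, within 12000 nM to 60000 nM, with a fair chance that only a limit is reported.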

Compound 4, half-maximal effective concentration: 16000 nM
For compound 4 the middle estimate is 1.6-fold (0.19 log units) above the measured one, within the range that was stated.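

In this assay, the exchange at this aromatic carbon now joins two measured compounds, and it reads a 1.3-fold lower number from compound 3 to compound 4 (0.10 log units; within the scatter). So methylsulfanyl, with no double bond outside the ring and fewer heavy atoms than methoxycarbonyl, cannot be told apart from it here, which the earlier compounds could not show because no two of them both carried a real number. The steps from the two compounds with a limit give only floors, an at least 1.5-fold lower number from compound 2 to compound 4 (0.19 log units; that floor lies within the scatter) and an at least 1.5-fold lower number from compound 1 to compound 4 (0.19 log units; that floor lies within the scatter), and the real size of each stays hidden, for compound 1 and compound 2 share one ceiling of the read-out: the limit of > 25000 nM in this assay, at which 2 of the 4 values shown sit.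

As far as these compounds go, whether a different kind of group at this place, such as an amine or a longer chain like butylsulfanyl, would shift the number beyond the scatter remains open. Also open, from the compounds shown here alone, is how far compound 1 and compound 2 really lie from compound 3 and compound 4, as their values are limits and not numbers.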